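Adding a methoxy group to compound 1

This account rests on a few compounds, and the source may have more. Where it says the series, first, only, none or still open, it means among the compounds named here.

Among the compounds with values here, in a functional assay on HT-1080 cells (Homo sapiens) for cytotoxicity, read by MTT assay, with a stated time of 72 h (a higher number here means a weaker inhibitor, a lower number a stronger inhibitor), compound 1 (`COc1cccc(/C=C2\CCC/C(=C\c3ccc(OC)c(OC)c3)C2=O)c1`) gives 4600 nM as the lower of the two numbers so far. Compound 2 (`COc1ccc(/C=C2\CCC/C(=C\c3ccc(Cl)cc3Cl)C2=O)cc1OC`) gives 10500 nM in the same test. Within the data shown here, the only measured step is modest but beyond the scatter: a 2.3-fold higher number from compound 1 to compound 2 (0.36 log units; beyond the scatter) with 2,4-dichlorophenyl in place of 3-methoxyphenyl. Compound 3 (`COc1cc(/C=C2\CCC/C(=C\c3ccc(OC)c(OC)c3)C2=O)cc(OC)c1`) instead carries methoxy in place of hydrogen on an aromatic carbon, meta to a large group and meta to a methoxy group (methoxy in place of hydrogen on an aromatic carbon). That single step swaps a whole substituted ring and gives no direction for this smaller change. In this assay no step beyond the scatter is therefore expected. The expected step is a 1.0-fold lower number from compound 1 to compound 3 (0.01 log units; within the scatter) and remains within the scatter. For compound 3 the estimate is 4500 nM with an expected range from 1800 nM to 11000 nM for repeat measurements.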

Compound 3, half-maximal inhibitory concentration: 2600 nM
Compound 3: the middle estimate sits 1.7-fold (0.24 log units) above what was measured; the measured number falls inside the stated range.
By their numbers in this assay, from the lowest: compounds 3 and 1 (each within the scatter of the next); then compound 2.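

In this assay, methoxy in place of hydrogen on this aromatic carbon, meta to a large group and meta to a methoxy group, comes with a 1.8-fold lower number from compound 1 to compound 3 (0.25 log units; within the scatter) and leaves compound 1 and compound 3 not separable in this test. Within the data shown here, this is the first step confined to a single group rather than a whole substituted ring, and it shows that this carbon accepts methoxy with no change beyond the scatter. No measurement here bears on why the number stays within the scatter.

The compounds shown leave open whether a different group on this carbon, such as a hydroxyl, an amine or a longer alkoxy chain, would move the number beyond the scatter. They also leave open whether methoxy would give the same small step on a ring other than this one.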